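Ring-nitrogen position at the benzylic amide terminus

This account rests on a few compounds, and the source may have more. Where it says the series, first, only, none or still open, it means among the compounds named here.

For the measured compounds named here, compound 2 `CN(C)CCN1CCN(C2=Nc3ccccc3C(CC(=O)NCc3ccccn3)N2c2ccc(-c3ccccc3)cc2)CC1` carries the higher of the two numbers measured so far in a functional assay on A2780 cells (Homo sapiens) for cytotoxicity, read by MTT assay, with a stated time of 48 h (on this read-out higher numbers stand for weaker inhibition and lower numbers for stronger inhibition), where compound 2 gives 4860 nM; compound 1 `COc1ccc(CNC(=O)CC2c3ccccc3N=C(N3CCN(CCN(C)C)CC3)N2c2ccc(-c3ccccc3)cc2)cc1` gives 1440 nM in this assay. Going by the values given here, the one measured step, a 3.4-fold higher number from compound 1 to compound 2 (0.53 log units; beyond the scatter), exchanges the 4-methoxyphenyl group for pyridin-2-yl at the same position and does not touch the new change. Compound 3 `CN(C)CCN1CCN(C2=Nc3ccccc3C(CC(=O)NCc3ccncc3)N2c2ccc(-c3ccccc3)cc2)CC1` differs from compound 2 only in the position of the ring nitrogen: pyridin-4-yl in place of pyridin-2-yl on a saturated chain carbon bound to an amide-type nitrogen. Among the compounds with values here, no measured pair speaks to moving the nitrogen within the pyridine ring, so the measured step gives only the scale on which this position responds. The expected outcome is a step of a 1.1-fold lower number from compound 2 to compound 3 (0.03 log units; within the scatter), not clearly beyond the scatter in either direction. Compound 3 is therefore estimated at 4500 nM in this assay, with a range from 1500 nM to 13000 nM.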

Compound 3, half-maximal inhibitory concentration: > 5000 nM
Compound 3: no number, only a limit (the forecaster's own chance of this, stated with the estimate: 5%); at least 1.1-fold (0.04 log units) between middle value and limit.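

Compound 3 reads as a limit and not as a number in this assay, the only such reading among the compounds shown: the limit of > 5000 nM in this assay, at which 1 of the 3 values shown sits. Moving the ring nitrogen gives an at least 1.0-fold higher number from compound 2 to compound 3 (0.01 log units; that floor lies within the scatter), so this floor does not separate the two pyridine isomers. The comparison with the 4-methoxyphenyl group is clearer, with an at least 3.4-fold higher number from compound 1 to compound 3 (0.54 log units; beyond the scatter), so the weaker reading seen with pyridin-2-yl also holds for pyridin-4-yl at this place.

Going by these compounds, how far compound 3 lies beyond its limit stays open, and with it the true size of the nitrogen move. A plain phenyl group at this place, or a pyridin-3-yl group, would show whether the step away from 4-methoxyphenyl follows the ring nitrogen or the loss of the methoxy group.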